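Swapping trifluoromethyl for chloro on a shared core

The compounds below may be only part of what the source reports. "The series", "measured", "known", "first", "only" and "open" are said of these compounds alone.

Measured compounds:
compound 1 `O=C1/C(=C/c2ccccc2F)CN(S(=O)(=O)c2ccccc2)C/C1=C\c1ccccc1F` — 5700 nM
compound 2 `O=C1/C(=C/c2ccccc2F)CN(S(=O)(=O)c2ccc(O[N+](=O)[O-])cc2)C/C1=C\c1ccccc1F` — 6200 nM
compound 3 `O=C1/C(=C/c2ccccc2F)CN(S(=O)(=O)c2ccc(C(F)(F)F)cc2)C/C1=C\c1ccccc1F` — 5200 nM

In a functional assay on SMMC-7721 cells (Homo sapiens) for cytotoxicity, read by MTT assay, with a stated time of 24 h (on this read-out lower numbers stand for stronger inhibition and higher numbers for weaker inhibition), compound 3 shows the lowest of the three numbers, yet both of its neighbours sit within the scatter: a 1.1-fold lower number from compound 1 to compound 3 (0.04 log units; within the scatter) and a 1.2-fold lower number from compound 2 to compound 3 (0.08 log units; within the scatter). The step from compound 1 to compound 2 is equally flat: a 1.1-fold higher number from compound 1 to compound 2 (0.04 log units; within the scatter). Across these three compounds the group on the aromatic carbon of the arylsulfonyl ring has barely moved the read-out.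

Compound 4 `O=C1/C(=C/c2ccccc2F)CN(S(=O)(=O)c2ccc(Cl)cc2)C/C1=C\c1ccccc1F` differs from compound 3 in one place: chloro in place of trifluoromethyl on an aromatic carbon. Within the data shown here, the steps that bear on this change are the two that exchange groups at the same aromatic carbon, from compound 1 to compound 3 and from compound 2 to compound 3, and both lie within the scatter. On that basis compound 4 is expected to land close to compound 3, with a step of a 1.1-fold higher number from compound 3 to compound 4 (0.02 log units; within the scatter) that stays inside the scatter. The estimate for compound 4 is 5500 nM, with a range from 2800 nM to 11000 nM.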

Compound 4, half-maximal inhibitory concentration: 4500 nM
For compound 4 the middle estimate is 1.2-fold (0.09 log units) above the measured one; measured number inside the range.
By their numbers in this assay, from the lowest: compounds 4, 3, 1 and 2 (each within the scatter of the next).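

In this assay, chloro at this place fits the same flat picture as the earlier groups: a 1.2-fold lower number from compound 3 to compound 4 (0.06 log units; within the scatter), a 1.4-fold lower number from compound 2 to compound 4 (0.14 log units; within the scatter) and a 1.3-fold lower number from compound 1 to compound 4 (0.10 log units; within the scatter). Hydrogen, nitrooxy, trifluoromethyl and chloro on this aromatic carbon, para to a large group, therefore all give numbers within the scatter of one another, and the exchange of trifluoromethyl for chloro adds a fourth group that leaves the read-out essentially unmoved. Nothing available accounts for this insensitivity at the position.

The compounds shown leave open whether a group of another kind at this aromatic carbon, such as an amine or a carboxylic acid, would move the number beyond the scatter. They also leave open whether this flatness would persist if the rest of the shared core were changed.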